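Cyanomethyl extension on the ring nitrogen substituent

A few compounds are considered here, and "the series" means these few. Any claim that something is new, unique, unknown or untested is made for them only; others in the source may bear on it.

Measured compounds:
compound 1, `COc1cc(OC)c2cc(-c3ccc(OCc4ccccc4)cc3)c(O)nc2c1`, 10000 nM
compound 2, `COc1ccc(-c2cc3c(OC)cc(OC)cc3n(C)c2=O)cc1`, 10000 nM

In a functional assay on PC-3 cells (Homo sapiens) for cytotoxicity, read by colorimetric assay and MTT assay (on this read-out higher numbers stand for weaker inhibition and lower numbers for stronger inhibition), compound 1 gives 10000 nM. In this assay compound 2 gives 10000 nM, level with compound 1 at the digits shown; the two values lie within the scatter of each other, so no order between them can be read. Both stand at the weak end of the range covered here.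

Compound 3, `COc1ccc(-c2cc3c(OC)cc(OC)cc3n(CCC#N)c2=O)cc1`, is not yet measured. It differs from compound 2 in one place: cyanomethyl in place of hydrogen on a saturated chain carbon bound to an aromatic nitrogen. Read one bond further out, the change is methyl to 2-cyanoethyl, with one hydrogen-bond acceptor entering and no donor.

For the measured compounds named here, no step between measured compounds has been recorded, so nothing yet shows how changes on this chain move the read-out. The expected step from compound 2 to compound 3 in this assay is no change at the digits printed from compound 2 to compound 3 (within the scatter), none beyond the scatter. Compound 3 is therefore estimated at 10000 nM, with a range of 5000 nM to 20000 nM.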

Compound 3, half-maximal inhibitory concentration: 10000 nM
Compound 3: the middle estimate sits on the measured number at the digits printed, within the range that was stated.
By their numbers in this assay, from the lowest: compounds 1, 2 and 3 (each within the scatter of the next).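

In this assay the first step recorded on this chain reads no change at the digits printed from compound 2 to compound 3 (within the scatter) for cyanomethyl in place of hydrogen on a saturated chain carbon bound to an aromatic nitrogen. Read as methyl to 2-cyanoethyl, the change brings in a nitrile with a hydrogen-bond acceptor and no donor, and compound 3 at 10000 nM stays level with compound 2 at the weak end of the range. Nothing measured alongside these compounds explains this result.

For the compounds shown here, with only this one step, it stays open whether any group at this place can move the read-out away from the weak end. An amine or a carboxylic acid in place of the nitrile, or a longer chain carrying either, would test that.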